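Dropping One Fluorine from the Sulfonamide Ring

The compounds below may be only part of what the source reports. "The series", "measured", "known", "first", "only" and "open" are said of these compounds alone.

In a functional assay on HCT-116 cells (Homo sapiens) for cytotoxicity, read by MTT assay, with a stated time of 72 h (on this read-out higher numbers stand for weaker inhibition and lower numbers for stronger inhibition), compound 2 `O=S(=O)(Nc1cc(-c2ccc3nccc(-c4ccc(Cn5cncn5)cc4)c3c2)cnc1Cl)c1ccc(F)cc1F` gives 36 nM, the higher of the two numbers recorded, while compound 1 `CN(C)Cc1ccc(-c2ccnc3ccc(-c4cnc(Cl)c(NS(=O)(=O)c5ccc(F)cc5F)c4)cc23)cc1` gives 24 nM; the step of a 1.5-fold higher number from compound 1 to compound 2 (0.18 log units; within the scatter) lies within the scatter. Compound 3 `O=S(=O)(Nc1cc(-c2ccc3nccc(-c4ccc(Cn5cncn5)cc4)c3c2)cnc1Cl)c1ccc(F)cc1` differs from compound 2 by hydrogen in place of fluoro on an aromatic carbon. Going by the values given here, no measured step touches this sulfonamide ring; the one measured step, from compound 1 to compound 2, alters a different group. The step from compound 2 to compound 3 is therefore expected to be a 1.3-fold higher number from compound 2 to compound 3 (0.10 log units; within the scatter), nothing beyond the scatter. Compound 3 is expected to give 45 nM, within a range of 15 nM to 140 nM.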

Compound 3, half-maximal inhibitory concentration: 33 nM
Compound 3: middle estimate off by 1.4-fold (0.13 log units), on the high side, and the stated range covers the measured number.
By their numbers in this assay, from the lowest: compounds 1, 3 and 2 (each within the scatter of the next).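

Going by these compounds alone, on the sulfonamide, 2,4-difluorophenyl gives way to 4-fluorophenyl in the first measured change to this ring, and in this assay this gives a 1.1-fold lower number from compound 2 to compound 3 (0.04 log units; within the scatter) for the whole molecule. The fluoro group ortho to a large group can therefore be replaced by hydrogen with no difference that this read-out can separate from scatter. Nothing available explains this result.

Still open, on these data alone, is whether the remaining fluoro group matters in the same way. Also open, as far as these compounds go, is what a chloro, methoxy or amino group would do in the position of the lost fluoro group.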